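This account rests on a few compounds, and the source may have more. Where it says the series, first, only, none or still open, it means among the compounds named here.

In a functional assay on A2780 cells (Homo sapiens) for antiproliferative activity, read by MTT assay, with a stated time of 48 h (a higher number here means a weaker inhibitor, a lower number a stronger inhibitor), compound 1 `CCNCC(=O)Nc1cc(OC)ccc1C(=O)c1ccc2c(c1)C=CC(C)(C)O2` gives 2070 nM. Compound 2 `COc1ccc(C(=O)c2ccc3c(c2)C=CC(C)(C)O3)c(NC(=O)CN(C)C)c1` carries dimethylamino in place of ethylamino on a saturated chain carbon bound to a carbonyl carbon and in this assay gives 1020 nM, a step of a 2.0-fold lower number from compound 1 to compound 2 (0.31 log units; beyond the scatter). Compound 3 `C=C(c1ccc(OC)cc1NC(=O)CNCC)c1ccc(OC)c2c1C=CC(C)(C)O2` is built on a different core; the difference between the two cores is not broken down here. In this assay compound 3 gives 2010 nM. Compound 4 `C=C(c1ccc(OC)cc1NC(=O)CN(C)C)c1ccc(OC)c2c1C=CC(C)(C)O2` is not yet measured; it differs from compound 3 by dimethylamino in place of ethylamino on a saturated chain carbon bound to a carbonyl carbon, the same change as that between compound 1 and compound 2, at the same place. For the measured compounds named here, the expectation for compound 4 rests on the one earlier step of a 2.0-fold lower number from compound 1 to compound 2 (0.31 log units; beyond the scatter) carrying over to the other core. Compound 4 is therefore expected to give 1000 nM in this assay, within an estimated range of 500 nM to 2000 nM, an estimated step of a 2.0-fold lower number from compound 3 to compound 4 (0.30 log units; within the scatter). A single precedent leaves that transfer uncertain.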

Compound 4, half-maximal inhibitory concentration: 670 nM
For compound 4 the middle estimate is 1.5-fold (0.17 log units) above the measured one; measured number inside the range.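

In this assay, dimethylamino in place of ethylamino gives a 3.0-fold lower number from compound 3 to compound 4 (0.48 log units; beyond the scatter), so the change runs the same way on the other core. The two steps cannot be told apart in size: the same change on two cores in this assay, a 2.0-fold lower number (0.31 log units; beyond the scatter) from compound 1 to compound 2 and a 3.0-fold lower number (0.48 log units; beyond the scatter) from compound 3 to compound 4, 1.5-fold (0.17 log units) apart, within the scatter of two such steps. This supports carrying the change across these two cores in this assay, but two pairs do not show that it would hold on any further core, nor do they explain the step.

The compounds shown leave open how other amines at this place, such as diethylamino, pyrrolidine or morpholine, would compare. Also open, from the compounds shown here alone, is how a longer chain carrying the dimethylamino group would behave on either core.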